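A few compounds are considered here, and "the series" means these few. Any claim that something is new, unique, unknown or untested is made for them only; others in the source may bear on it.

Working notes, values in a functional assay on HeLa cells (Homo sapiens) for inhibition, read by CCK-8 assay, with a stated time of 48 h; on this read-out lower numbers stand for stronger inhibition and higher numbers for weaker inhibition:

- compound 1 `O=S(=O)(NCCNC(=S)Nc1cc(C(F)(F)F)cc(C(F)(F)F)c1)c1ccc(-c2ccccc2OCc2cccc(O)c2)s1`: 14900 nM
- compound 2 `COc1ccc(Oc2ccccc2-c2ccsc2S(=O)(=O)NCCNC(=S)Nc2cc(C(F)(F)F)cc(C(F)(F)F)c2)cc1OC`: 6400 nM
- compound 3 `Cc1ccc(-c2ccsc2S(=O)(=O)NCCNC(=O)Nc2cc(Cl)cc(Cl)c2)c(Oc2ccc(O)c(O)c2)c1`: 6500 nM

Compound 2 has the lowest number of the three, but its gap to compound 3 lies within the scatter, so those two count as level. Its gap to compound 1 lies beyond the scatter, with compound 1 on the weaker side.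

Compound 4 `COc1ccc(Oc2ccc(C(C)C)cc2-c2ccsc2S(=O)(=O)NCCNC(=S)Nc2cc(C(F)(F)F)cc(C(F)(F)F)c2)cc1OC` is compound 2 with one change, isopropyl in place of hydrogen on an aromatic carbon, para to a 3,4-dimethoxyphenoxy group.

Within the data shown here, no measured pair differs in one place, so nothing here isolates the effect of this change. The three values also lie close together. In this assay, only a small change towards a lower number is expected, and it is not expected to leave the scatter. The expected step is a 1.3-fold lower number from compound 2 to compound 4 (0.11 log units; within the scatter). For compound 4 the estimated value is 5000 nM, with an expected range of 1800 nM to 14000 nM.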

Compound 4, half-maximal inhibitory concentration: 8300 nM
For compound 4 the middle estimate is 1.7-fold (0.22 log units) below the measured one, and the stated range covers the measured number.
By their numbers in this assay, from the lowest: compounds 2, 3, 4 and 1 (each within the scatter of the next, the first and the last beyond it).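

In this assay, among these compounds, isopropyl in place of hydrogen on an aromatic carbon, para to a 3,4-dimethoxyphenoxy group, gives a 1.3-fold higher number from compound 2 to compound 4 (0.11 log units; within the scatter), the first comparison that differs in one place. Compound 2 and compound 4 therefore count as level: this position accepts a group of three carbons, with no ring and no hydrogen-bond donor or acceptor, without a shift that leaves the scatter. As this is a single step at a single position, it sets no trend for other substituents.

From the compounds shown here alone, whether an amine, a carboxylic acid or a longer chain at this position would give a step beyond the scatter remains open, as does whether isopropyl gives the same result on the core of compound 1 or compound 3. No measurement at hand explains why this step stays so small.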